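Adding a nitro group to the phenoxy arm of compound 1

This account rests on a few compounds, and the source may have more. Where it says the series, first, only, none or still open, it means among the compounds named here.

Measured compounds:
compound 1 `O=C(CSc1nc2ccccc2s1)N/N=C/c1ccc(Oc2ccccc2)cc1`: 5.6
compound 2 `Fc1ccc(Oc2ccc(/C=N/Nc3nc4ccccc4s3)cc2)cc1`: 5
compound 3 `C(=N/Nc1nc2ccccc2s1)\c1ccc(Oc2ccccc2)cc1`: 5.2

In a physicochemical assay for lipophilicity, in phosphate buffer, measured as octanol-water partition, with a stated time of 24 h (a lower number here means a more polar compound, a higher number a more lipophilic compound), compound 1 gives 5.6, the highest of the three numbers, standing beyond the scatter above both compound 3 and compound 2. The unmeasured compound 4 `O=C(CSc1nc2ccccc2s1)N/N=C/c1ccc(Oc2ccc([N+](=O)[O-])cc2)cc1` differs from compound 1 by nitro in place of hydrogen on an aromatic carbon. Among the measured compounds shown here, the only measured step, a number 0.20 log units higher from compound 2 to compound 3 (within the scatter), concerns a different change and does not directly bear on a nitro group. For the measured compounds named here, no measured pair here tests nitro in place of hydrogen, so the expectation rests loosely on the shared core. Compound 4 is expected to sit close to compound 1, with an estimated step of a number 0.20 log units lower from compound 1 to compound 4 (within the scatter). Compound 4 is estimated at 5.4, in a range from 4.9 to 5.9.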

Compound 4, partition coefficient: 5.3
For compound 4 the middle estimate is 0.10 log units above the measured one, within the range that was stated.
By their numbers in this assay, from the lowest: compounds 2, 3, 4 and 1 (each within the scatter of the next, the first and the last beyond it).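

Compound 4 gives the first measured test of this position: on an aromatic carbon para to a large group, nitro stands in place of hydrogen and brings 3 heavy atoms. In this assay the change from phenoxy to 4-nitrophenoxy reads as a number 0.30 log units lower from compound 1 to compound 4 (within the scatter) and so cannot be told apart from no change at all. From the compounds shown here alone, whether an amine or a carboxylic acid at this same place would give a step beyond the scatter remains open. Nothing shown here offers a measured explanation for the size of this step.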